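The source may hold more compounds than are shown below. What is called first, only, known or untested is meant among the compounds shown, and "the series" means these compounds.

Compound 3, `N#C[C@@H]1CCCN1C(=O)[C@@H]1C[C@H](C(N)=O)CN1`, gives 47% in an assay on the whole organism (plasma, strain Sprague-Dawley) for inhibition of Dipeptidyl peptidase 4 (Rattus norvegicus), with a stated time of 6 h, at a dose of 1 mg/kg by the oral route; a lower number here means less inhibition, a higher number more inhibition at the dose given (going by the name of the read-out). That is the largest of the three numbers shown, yet every step to the other two lies within the scatter: compound 2, `CCN(CC)C(=O)[C@@H]1CN[C@H](C(=O)N2CCC[C@H]2C#N)C1`, gives 43%, and compound 1, `C=CC[C@@H]1CN[C@H](C(=O)N2CCC[C@H]2C#N)C1`, gives 38% in this assay . The change to compound 4, `CCN(C)C(=O)[C@@H]1CN[C@H](C(=O)N2CCC[C@H]2C#N)C1`, concerns the group on the carbonyl carbon: ethyl(methyl)amino in place of amino on a carbonyl carbon. The measured steps that bear on it are all small. Swapping allyl for diethylcarbamoyl gave a number 5 percentage points higher from compound 1 to compound 2 (within the scatter), swapping allyl for carbamoyl gave a number 9 percentage points higher from compound 1 to compound 3 (within the scatter), and the closest comparison, amino in place of diethylamino on the same carbonyl carbon, gave a number 4 percentage points higher from compound 2 to compound 3 (within the scatter). Going from amino to ethyl(methyl)amino runs in the opposite direction to that last step, and all three steps sit within the scatter, so no step beyond the scatter is expected in this assay . The expected step is a number 3 percentage points lower from compound 3 to compound 4 (within the scatter). Compound 4 is therefore estimated at 44%, within a range from 30% to 58%.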

Compound 4, a percentage reported as inhibition, in the whole organism at one dose (the size of the read-out at that dose, not a potency): 71%
For compound 4 the middle estimate is 27 percentage points below the measured one, outside the stated range (above it).
By their numbers in this assay, from the lowest: compounds 1, 2 and 3 (each within the scatter of the next); then compound 4.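

At this carbonyl carbon, the group on the nitrogen can clearly change the result in this assay: ethyl(methyl)amino in place of amino gives a number 24 percentage points higher from compound 3 to compound 4 (beyond the scatter), and hydrogen in place of methyl on a saturated chain carbon bound to an amide-type nitrogen gives a number 28 percentage points higher from compound 2 to compound 4 (beyond the scatter). The read-out therefore does not climb steadily from amino through ethyl(methyl)amino to diethylamino, since compound 2 and compound 3 lie within the scatter of each other while compound 4 stands clear of both, and ethyl(methyl)carbamoyl in place of allyl gives a number 33 percentage points higher from compound 1 to compound 4 (beyond the scatter). No measurement here explains the rise.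

The compounds shown leave open whether methylamino or dimethylamino on the same carbonyl carbon would share this gain. They also leave open whether a ring amide such as pyrrolidin-1-yl would keep it.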